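Lengthening the Unsaturated Side Chain of Compound 1

The source may report more compounds than this note shows. Statements on the series, on what has been measured and on what is new or still open speak of the compounds shown alone.

Measured so far:
compound 1, `O=C/C=C/c1ccc2c(c1)O[C@@H](CO)[C@H](c1ccc(O)c(O)c1)O2`: 7600 nM
compound 2, `COc1ccc([C@@H]2Oc3ccc(/C=C/C=O)cc3O[C@H]2COC(C)=O)cc1OC`: 5600 nM

Both were tested in a functional assay on HCT-116 cells (Homo sapiens) for antiproliferative activity, read by sulforhodamine B assay, with a stated time of 72 h; on this read-out lower numbers stand for stronger inhibition and higher numbers for weaker inhibition. Compound 1 gives 7600 nM and compound 2 gives 5600 nM; these two numbers lie within the usual scatter of each other, so neither compound can be called the stronger one. Compound 3, `CC(=O)/C=C/C=C/c1ccc2c(c1)O[C@@H](CO)[C@H](c1ccc(O)c(O)c1)O2`, has not yet been measured. It differs from compound 1 in one place: 2-acetylethenyl in place of formyl on a double-bonded chain carbon bound to a double-bonded chain carbon. For the measured compounds named here, no measured pair shows this kind of change, so its effect is unknown. For compound 3 a step of a 1.2-fold lower number from compound 1 to compound 3 (0.07 log units; within the scatter) is expected, small enough to stay within the scatter. Compound 3 is therefore estimated at 6500 nM, with a range from 2200 nM to 19000 nM.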

Compound 3, half-maximal inhibitory concentration: > 100000 nM
Compound 3 ended at the assay's limit (the forecaster's own chance of this, stated with the estimate: 5%); middle value at least 15-fold (1.18 log units) from the limit.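

In this assay, 2-acetylethenyl in place of formyl gives an at least 13-fold higher number from compound 1 to compound 3 (1.11 log units; beyond the scatter), so this end of the side chain does not accept every change. Compounds 1 and 2 both carry the formyl group here, so neither could show this sensitivity. Compound 3 reads as a limit of the assay and not as a number, so the full size of the loss stays unknown: the limit of > 100000 nM in this assay, at which 1 of the 3 values shown sits.

The compounds shown leave open whether the extra ethenyl unit or the acetyl end carries the loss. They also leave open how a carboxylic acid or an amine in place of formyl would read.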